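The compounds below may be only part of what the source reports. "The series", "measured", "known", "first", "only" and "open" are said of these compounds alone.

Compound 1 `Cc1cccc(-c2ccnc(C(=O)Nc3ccc(Oc4ccnc5[nH]ccc45)c(F)c3)c2)c1` gives 9120 nM in a functional assay on MCF7 cells (Homo sapiens) for cytotoxicity, read by MTT assay, with a stated time of 72 h; on this read-out higher numbers stand for weaker inhibition and lower numbers for stronger inhibition. Compound 2 `CCc1ccc(-c2ccnc(C(=O)Nc3ccc(Oc4ccnc5[nH]ccc45)c(F)c3)c2)cc1` gives 7470 nM in this assay.

On these two numbers compound 2 holds the lowest value, and its nearest neighbour is compound 1, the step being a 1.2-fold lower number from compound 1 to compound 2 (0.09 log units; within the scatter), so the two compounds cannot be told apart on this read-out. Compound 3 `O=C(Nc1ccc(Oc2ccnc3[nH]ccc23)c(F)c1)c1cc(-c2ccc(C(F)(F)F)cc2)ccn1` differs from compound 2 by trifluoromethyl in place of ethyl on an aromatic carbon. For the measured compounds named here, only one measured step exists to lean on, the one from compound 1 to compound 2, which put 4-ethylphenyl in place of 3-methylphenyl and stayed within the scatter; no measured step shows a trifluoromethyl entering at this place. The expected step for compound 3 is therefore a 1.1-fold lower number from compound 2 to compound 3 (0.03 log units; within the scatter), with no direction favoured beyond the scatter. The estimate for compound 3 in this assay is 7000 nM, expected to lie between 2500 nM and 20000 nM.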

Compound 3, half-maximal inhibitory concentration: 8550 nM
Beside the measured number, compound 3's estimate is 1.2-fold (0.09 log units) below it, within the range that was stated.
By their numbers in this assay, from the lowest: compounds 2, 3 and 1 (each within the scatter of the next).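

In this assay the swap of ethyl for trifluoromethyl at this place, on an aromatic carbon para to a large group, gives a 1.1-fold higher number from compound 2 to compound 3 (0.06 log units; within the scatter) and does not separate the two compounds, even though the entering group carries fluorine instead of a plain carbon chain. Set against the 3-methylphenyl group, the 4-(trifluoromethyl)phenyl group gives a 1.1-fold lower number from compound 1 to compound 3 (0.03 log units; within the scatter) and so all three compounds now sit within the scatter of one another, whichever of these three groups the outer phenyl ring carries. Nothing measured alongside these numbers speaks to why the read-out stays so level.

The compounds shown leave open whether an amine, a carboxylic acid or a chain longer than ethyl at this place would move the number beyond the scatter. They also leave open whether this level picture holds on any cell line other than this one.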